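Replacing 4-fluorophenyl with cyclopropyl on a weak compound

This account rests on a few compounds, and the source may have more. Where it says the series, first, only, none or still open, it means among the compounds named here.

Measured in a functional assay on PC-3 cells (Homo sapiens) for inhibition, read by MTT assay, with a stated time of 48 h; on this read-out lower numbers stand for stronger inhibition and higher numbers for weaker inhibition:
Compound 1 `COc1cc(-c2nnc(S)n2-c2ccc(N(C)C)cc2)cc(OC)c1OC`: > 60000 nM (a limit, not a number)
Compound 2 `COc1cc(-c2nnc(SCC(=O)c3ccc(F)cc3)n2-c2ccc(N(C)C)cc2)cc(OC)c1OC`: 42300 nM

Among the compounds with values here, compound 2 holds the only true number so far, 42300 nM. The entry for compound 1 is a limit. Within the data shown here, the one measured step is an at least 1.4-fold lower number from compound 1 to compound 2 (0.15 log units; that floor lies within the scatter). It rests on (the limit of > 60000 nM in this assay, at which 1 of the 2 values shown sits), and it adds the whole ((4-fluorophenyl)carbonyl)methyl group at once, so it cannot show what the 4-fluorophenyl part contributes alone.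

Compound 3 `COc1cc(-c2nnc(SCC(=O)C3CC3)n2-c2ccc(N(C)C)cc2)cc(OC)c1OC` has cyclopropyl in place of 4-fluorophenyl on a carbonyl carbon. Among the measured compounds shown here, with that single step as the only guide, no change beyond the scatter is expected in this assay, in either direction. Compound 3 is expected at 45000 nM, with an estimated range of 20000 nM to 85000 nM. The expected change is a 1.1-fold higher number from compound 2 to compound 3 (0.03 log units; within the scatter).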

Compound 3, half-maximal inhibitory concentration: 45900 nM
Compound 3: middle estimate off by 1.0-fold (0.01 log units), on the low side; the measured number falls inside the stated range.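

In this assay, putting cyclopropyl in place of 4-fluorophenyl on a carbonyl carbon gives a 1.1-fold higher number from compound 2 to compound 3 (0.04 log units; within the scatter), so here the six-membered aromatic ring can be exchanged for a three-membered ring with no change beyond the scatter. The full side chain on the sulfur can now be compared in a second form, (cyclopropylcarbonyl)methyl, which gives an at least 1.3-fold lower number from compound 1 to compound 3 (0.11 log units; that floor lies within the scatter). The value of compound 1 is a limit, not a number, so this step gives only a floor and not a true size: the limit of > 60000 nM in this assay, at which 1 of the 3 values shown sits.

As far as these compounds go, it remains open whether any other group on this carbonyl carbon, such as an amine or a carboxylic acid, would move the number beyond the scatter. Also open, from the compounds shown here alone, is how changes to the shared core, which stays the same in all three compounds, would affect it.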